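From an Allyl to an Allyloxy Side Chain

This account rests on a few compounds, and the source may have more. Where it says the series, first, only, none or still open, it means among the compounds named here.

Compound 1 `CCCCC[C@@H]1CC=CC(=O)O1`: 16 ug/mL
Compound 2 `CCC1CC=CC(=O)O1`: "not determined" (no result reported)
Compound 3 `C=CCCC1CC=CC(=O)O1`: "not determined" (no result reported)

In a functional assay on HL-60 cells (Homo sapiens) for cytotoxicity, read by MTT assay, with a stated time of 72 h (a lower number here means a stronger inhibitor, a higher number a weaker inhibitor), only compound 1 has a number. The entry for compound 3 reads "not determined" (no result reported), so compound 3 offers no starting value and cannot be ranked against compound 1.

Compound 4 `C=CCOCC1CC=CC(=O)O1` has not yet been measured. The change is allyloxy in place of allyl on a saturated chain carbon bound to a saturated ring carbon, which puts allyloxy in place of allyl on a saturated chain carbon bound to a saturated ring carbon.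

Within the data shown here, no two measured compounds differ in just one place, so the data contain no measured step to serve as a guide. For this change in this assay, the expectation is therefore no step beyond the scatter, in either direction. Among the measured compounds shown here, the only number to lean on is that of compound 1 at 16 ug/mL.

For compound 4 the expected value is 25 ug/mL, with an estimated range of 10 ug/mL to 70 ug/mL.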

Compound 4, half-maximal inhibitory concentration: 25.5 ug/mL
Compound 4: the middle estimate sits 1.0-fold (0.01 log units) below what was measured, and the stated range covers the measured number.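

In this assay, among these compounds, compound 3 has no single number, so no step from it to compound 4 can be read. What putting allyloxy in place of allyl does to the value stays open, and no supporting finding is available to explain the result of compound 4.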